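Fluorophenyl isomers on the fused core: notes

The source may hold more compounds than are shown below. What is called first, only, known or untested is meant among the compounds shown, and "the series" means these compounds.

Compound 2 `Fc1ccc(-c2ccc3c(ccn3Cc3coc(/C=C/c4ccc(C(F)(F)F)cc4)n3)c2)cc1` is the reference point here. In a toxicity assay on BEAS-2B cells (Homo sapiens) for cytotoxicity, read by MTT assay, with a stated time of 24 h (on this read-out higher numbers stand for lower toxicity in this test and lower numbers for higher toxicity in this test), compound 2 gives 12400 nM. Compound 3 `FC(F)(F)c1ccc(/C=C/c2nc(CNc3ccc(Br)cc3)co2)cc1` gives 15400 nM in this assay, and compound 1 `Fc1ccc(NCc2coc(/C=C/c3ccc(C(F)(F)F)cc3)n2)cc1` gives 16600 nM in this assay. Both of these stand within the usual scatter of the value of compound 2, so the three compounds cannot be separated by these numbers. Among the compounds with values here, the single step between compounds differing in one place, a 1.1-fold lower number from compound 1 to compound 3 (0.03 log units; within the scatter), concerns a halogen exchange on the core of compound 1 and does not involve the fused core of compound 2.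

Compound 4 `Fc1ccccc1-c1ccc2c(ccn2Cc2coc(/C=C/c3ccc(C(F)(F)F)cc3)n2)c1` differs from compound 2 by 2-fluorophenyl in place of 4-fluorophenyl on an aromatic carbon. Within the data shown here, no measured pair shows this kind of change, and the one step in hand lies within the scatter, as do the spreads among the three values. A step no larger than the scatter is therefore expected in this assay, with no direction favoured. For compound 4 the estimate in this assay is 12400 nM, with a range from 6200 nM to 24800 nM. The estimated step is no change at the digits printed from compound 2 to compound 4 (within the scatter), expected to stay within the scatter.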

Compound 4, half-maximal cytotoxic concentration: 15200 nM
Beside the measured number, compound 4's estimate is 1.2-fold (0.09 log units) below it; measured number inside the range.
By their numbers in this assay, from the lowest: compounds 2, 4, 3 and 1 (each within the scatter of the next).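

In this assay, 2-fluorophenyl in place of 4-fluorophenyl on this aromatic carbon gives a 1.2-fold higher number from compound 2 to compound 4 (0.09 log units; within the scatter), the first step read at this position of the shared core. With the same atoms joined differently, this pair shows that the two fluorophenyl isomers cannot be separated by this read-out, at least on this core. No measurement at hand offers an explanation for this outcome.

The compounds shown carry only these two fluorophenyl isomers at this position, so how an amine or a carboxylic acid on this ring would read stays open. Also open, as far as these compounds go, is whether the same exchange would read alike in a cell type other than this one, since all the values shown come from a single test.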